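Chloro on the phenyl ring of compound 3

This account rests on a few compounds, and the source may have more. Where it says the series, first, only, none or still open, it means among the compounds named here.

- compound 1 `COc1ccccc1/C=C/C(=O)c1c(O)cc2occc2c1OC` gives 23500 nM
- compound 2 `COc1c(C(=O)/C=C/c2ccc(Cl)cc2)c(O)c(Br)c2occc12` gives 4070 nM
- compound 3 `C=CCc1c(O)c(C(=O)/C=C/c2ccccc2)c(OC)c2ccoc12` gives 4920 nM

In a functional assay on DU-145 cells (Homo sapiens) for inhibition, with a stated time of 48 h (on this read-out higher numbers stand for weaker inhibition of growth and lower numbers for stronger inhibition of growth), compound 3 stands within the scatter of compound 2, and the number of compound 1 lies beyond the scatter above it. Compound 4 `C=CCc1c(O)c(C(=O)/C=C/c2ccc(Cl)cc2)c(OC)c2ccoc12` has chloro in place of hydrogen on an aromatic carbon, para to a large group chloro in place of hydrogen on an aromatic carbon and so turns phenyl to 4-chlorophenyl. Within the data shown here, no measured pair isolates this change. Compound 2 carries 4-chlorophenyl with 4070 nM but also differs elsewhere from compound 3, so in this assay no step beyond the scatter is expected. The estimated step of a 1.2-fold lower number from compound 3 to compound 4 (0.09 log units; within the scatter) is small, toward stronger inhibition of growth. For compound 4 the estimated value is 4000 nM (expected range 1700 nM to 9500 nM).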

Compound 4, concentration for 50% growth inhibition: 3850 nM
Estimate against measurement, compound 4: 1.0-fold (0.02 log units) above; the measured number falls inside the stated range.
By their numbers in this assay, from the lowest: compounds 4, 2 and 3 (each within the scatter of the next); then compound 1.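

In this assay, this position now has a measured pair: chloro in place of hydrogen, turning phenyl to 4-chlorophenyl, gives a 1.3-fold lower number from compound 3 to compound 4 (0.11 log units; within the scatter). With 4-chlorophenyl common to both compounds, allyl in place of bromo on an aromatic carbon gives a 1.1-fold lower number from compound 2 to compound 4 (0.02 log units; within the scatter), so neither single change moves the number beyond the scatter. Nothing available bears on the reason for either result.

On these data alone, whether an amine, a carboxylic acid or a nitrile in place of chloro would give a step beyond the scatter remains open. Compound 1 differs from the others in more than one place, so its higher number cannot be assigned to any single change.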